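Fluorophenyl isomers on a shared sulfonamide hydrazide scaffold

A few compounds are considered here, and "the series" means these few. Any claim that something is new, unique, unknown or untested is made for them only; others in the source may bear on it.

Compound 1 `O=C(NNC(=O)c1ccccc1F)c1cccc(NS(=O)(=O)c2cnc(O)nc2O)c1` is tested in a functional assay on SGC-7901 cells (Homo sapiens) for antiproliferative activity, read by MTT assay, with a stated time of 24 h; a lower number here means a stronger inhibitor, a higher number a weaker inhibitor. In this assay compound 1 gives > 20000 nM, which is a limit of the assay and not a number. Compound 2 `O=C(NNC(=O)c1cccc(NS(=O)(=O)c2cnc(O)nc2O)c1)c1ccc(F)cc1` carries 4-fluorophenyl in place of 2-fluorophenyl on a carbonyl carbon. In this assay compound 2 likewise gives only a limit, > 20000 nM. The resulting step, a step that the two limits leave unreadable from compound 1 to compound 2, therefore cannot be sized. Compound 3 `O=C(NNC(=O)c1ccccc1NS(=O)(=O)c1cnc(O)nc1O)c1ccccc1F` differs from compound 1 in its core; that difference is not broken down here. In this assay compound 3 gives > 20000 nM, again a limit. Compound 4 `O=C(NNC(=O)c1ccccc1NS(=O)(=O)c1cnc(O)nc1O)c1ccc(F)cc1` remains to be measured; it carries 4-fluorophenyl in place of 2-fluorophenyl on a carbonyl carbon, the same change as from compound 1 to compound 2, at the same place. Because (the limit of > 20000 nM in this assay, at which 3 of the 3 values shown sit), the step is expected to be a step that the limit leaves unreadable from compound 3 to compound 4, most likely ending at the limit once more. For compound 4 the estimated value in this assay is 30000 nM, within an expected range from 12000 nM to 80000 nM.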

Compound 4, half-maximal inhibitory concentration: > 20000 nM
Compound 4: no number, only a limit; the forecaster's own chance of this, stated with the estimate: 85%; the middle value does not contradict the limit.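

Within the data shown here, compound 3 and compound 4 both stand only at a limit of the assay, so no step between them can be read: the limit of > 20000 nM in this assay, at which 4 of the 4 values shown sit. The compounds shown leave open how strongly any of them acts in this assay and whether 2-fluorophenyl and 4-fluorophenyl differ at all.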